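Fluoro to nitro: a single swap on compound 1

A few compounds are considered here, and "the series" means these few. Any claim that something is new, unique, unknown or untested is made for them only; others in the source may bear on it.

Two compounds have results so far in a functional assay on COLO 205 cells (Homo sapiens) for inhibition, read by sulforhodamine B assay, with a stated time of 48 h, tested at 50 uM (a higher number here means more inhibition of growth at the concentration tested, a lower number less inhibition of growth), and the two sit level, within the usual scatter. Compound 1 (`O=C1C(=O)N(CCCCCn2cc(COc3cc(=O)oc4ccccc34)nn2)c2ccc(F)cc21`) gives 56% and compound 2 (`O=C1C(=O)N(CCCn2cc(COc3cc(=O)oc4ccccc34)nn2)c2ccc(I)cc21`) gives 56% at the single concentration tested. Neither compound stands out, so compound 1 is a middling reference only in the sense that nothing yet lies on either side of it.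

Compound 3 (`O=C1C(=O)N(CCCCCn2cc(COc3cc(=O)oc4ccccc34)nn2)c2ccc([N+](=O)[O-])cc21`) has not been measured. It keeps the core of compound 1 and carries nitro in place of fluoro on an aromatic carbon, with the chain unchanged. For the measured compounds named here, no measured pair here isolates a single structural change, so there is no direct guide to how large this step will be. With so little evidence, the expectation is no step beyond the scatter, in either direction, and the range has to stay wide. The estimated step is a number 1 percentage points lower from compound 1 to compound 3 (within the scatter) and it is not expected to exceed the scatter. Compound 3 is expected at 55% with a likely range of 38% to 72% in this assay when it is run.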

Compound 3, percent growth inhibition at one concentration: 23%
For compound 3 the middle estimate is 32 percentage points above the measured one, outside the stated range (below it).
By their numbers in this assay, from the lowest: compound 3; then compounds 1 and 2 (each within the scatter of the next).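

Swapping fluoro for nitro, with the chain unchanged, gives the first comparison that isolates a single structural change in this assay, and the result is a number 33 percentage points lower from compound 1 to compound 3 (beyond the scatter). This position on the aromatic ring, meta to a fused ring and para to a fused ring, is therefore not indifferent to the group it carries, at least for this pair: fluoro, with one heavy atom and no hydrogen-bond acceptors, is replaced by nitro, with three heavy atoms and two hydrogen-bond acceptors. Which of the differences between the two groups matters cannot be told, as no supporting measurement bears on the result.

A single swap cannot show whether the lower growth inhibition belongs to nitro alone or would also appear with other groups at this position, such as an amine, a nitrile or a plain hydrogen. It also leaves open whether the same swap would produce a step of similar size on a shorter or longer chain, or at a different position on the same ring.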